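Replacing Pyridin-2-yl with 2-(4-Chlorophenyl)ethenyl

A few compounds are considered here, and "the series" means these few. Any claim that something is new, unique, unknown or untested is made for them only; others in the source may bear on it.

Of the compounds shown here, three that share one core have been tested in an assay on CHO cells for displacement of a labelled ligand from adenosine receptor A1 (Homo sapiens), read by scintillation counting, tested at 10 uM; on this read-out higher numbers stand for more inhibition at the one concentration tested (going by the name of the read-out) and lower numbers for less inhibition. Compound 1 `CC(C)(C)c1csc(N)c1C(=O)c1ccc(Cl)cc1` gives 1%, compound 2 `Cc1c(-c2ccccc2)sc(N)c1C(=O)c1ccc(Cl)cc1` gives 1% and compound 3 `CC(C)(C)Cc1c(-c2ccccn2)sc(N)c1C(=O)c1ccc(Cl)cc1` gives 1%. Compound 3 thus stands level with compounds 1 and 2 at the digits shown; its nearest neighbour is compound 1 and its furthest is compound 2, and neither gap reaches beyond the scatter of this assay. Compound 4 `CC(C)(C)Cc1c(/C=C/c2ccc(Cl)cc2)sc(N)c1C(=O)c1ccc(Cl)cc1` differs from compound 3 in one place: 2-(4-chlorophenyl)ethenyl in place of pyridin-2-yl on an aromatic carbon. For the measured compounds named here, no pair of measured compounds differs in a single place, so no measured step guides this change. Going by the values given here, because compound 3 gives 1% and none of the measured compounds rises above that level, the step of a number 1 percentage points higher from compound 3 to compound 4 (within the scatter) is expected to stay within the scatter. Compound 4 is therefore estimated at 2%, with a range from -8% to 15%.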

Compound 4, a percentage reported as inhibition, at one concentration (the size of the read-out at that concentration, not a potency): 1%
Compound 4: middle estimate off by 1 percentage points, on the high side; low and high end bracket the measured number.
By their numbers in this assay, from the lowest: compounds 1, 2, 3 and 4 (each within the scatter of the next).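

In this assay, putting 2-(4-chlorophenyl)ethenyl in place of pyridin-2-yl on the aromatic carbon next to the ring sulfur gives no change at the digits printed from compound 3 to compound 4 (within the scatter). For the compounds shown here, this is the first comparison that changes one place only, and it shows that at this position a group of 9 heavy atoms with 0 hydrogen-bond acceptors reads the same as one of 6 heavy atoms with 1 hydrogen-bond acceptor. Nothing available explains this result.

Still open, as far as these compounds go, is whether any group at this position can raise the inhibition at all, for instance a carboxylic acid or an amine such as morpholine in place of 2-(4-chlorophenyl)ethenyl.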